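Trifluoromethyl for Methyl on the Sulfonyl Aryl Ring

The source may hold more compounds than are shown below. What is called first, only, known or untested is meant among the compounds shown, and "the series" means these compounds.

Measured compounds:
compound 1 `Cn1c(C(=O)NCc2ccc(S(=O)(=O)c3ccccc3)cc2)cc2cnccc21` — > 10000 nM
compound 2 `O=C(Nc1ccc(S(=O)(=O)N2CCCCC2)cc1)c1cc2cnccc2[nH]1` — > 10000 nM
compound 3 `Cc1cccc(S(=O)(=O)c2ccc(CNC(=O)c3cc4cnccc4[nH]3)cc2)c1` — 8 nM

In an assay for inhibition of Nicotinamide phosphoribosyltransferase (Homo sapiens), read by mass spectrometry, with stated times of 15 min and 30 min (a higher number here means a weaker inhibitor, a lower number a stronger inhibitor), compound 1 gives only a limit, > 10000 nM. Compound 2 likewise gives only a limit, > 10000 nM. Going by the values given here, compound 3 is the one compound with a number, 8 nM; the other two sit at the limit of > 10000 nM in this assay, at which 2 of the 3 values shown sit. Compound 4 `O=C(NCc1ccc(S(=O)(=O)c2cccc(C(F)(F)F)c2)cc1)c1cc2cnccc2[nH]1` is not yet measured. It differs from compound 3 by trifluoromethyl in place of methyl on an aromatic carbon. Among the compounds with values here, no step between two measured compounds is available to size this change, so it is expected to stay within the usual scatter, with no clear direction. Compound 4 is therefore estimated at 12 nM, between 4 nM and 40 nM, which is expected to mean a step of a 1.5-fold higher number from compound 3 to compound 4 (0.18 log units; within the scatter).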

Compound 4, half-maximal inhibitory concentration: 8 nM
Compound 4: middle estimate off by 1.5-fold (0.18 log units), on the high side, within the range that was stated.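

In this assay, trifluoromethyl in place of methyl on this aromatic carbon gives no change at the digits printed from compound 3 to compound 4 (within the scatter), the first step shown between two compounds that differ in one place. This place therefore takes the four heavy atoms of trifluoromethyl as readily as the one of methyl. Nothing shown here accounts for this flat step.

What the compounds leave open is whether this tolerance extends to other groups at this place, such as an amine, a carboxylic acid or a longer chain.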